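An Extra Ring Nitrogen on the Amide Heteroaryl

This account rests on a few compounds, and the source may have more. Where it says the series, first, only, none or still open, it means among the compounds named here.

Compound 1 `O=C(NCc1ccc(S(=O)(=O)c2ccccc2)cc1)c1ccc2nccn2c1` is tested in an assay for inhibition of Nicotinamide phosphoribosyltransferase (Homo sapiens), read by mass spectrometry, with stated times of 15 min and 30 min (a lower number here means a stronger inhibitor, a higher number a weaker inhibitor), where compound 1 gives 18 nM. Compound 2 `O=C(NCc1ccc(S(=O)(=O)c2ccccc2C(F)(F)F)cc1)c1cc2cnccc2[nH]1`, built on a different heteroaryl amide and a substituted aryl sulfone, gives 24 nM in this assay; the gap between compound 1 and compound 2 lies within the usual scatter, so the two sit at one level. Compound 3 `Cn1c(C(=O)NCc2ccc(S(=O)(=O)c3ccccc3)cc2)cc2cnccc21` reaches only > 10000 nM in this assay, which is a limit of the assay and not a number (the limit of > 10000 nM in this assay, at which 1 of the 3 values shown sits). Compound 4 `O=C(NCc1ccc(S(=O)(=O)c2ccccc2)cc1)c1cnc2nccn2c1` has not yet been measured. It differs from compound 1 by a group of 9 heavy atoms (6 carbon, 3 nitrogen; one five-membered aromatic ring with 2 hetero atoms, one six-membered aromatic ring with 2 hetero atoms) in place of a group of 9 heavy atoms (7 carbon, 2 nitrogen; one five-membered aromatic ring with 2 hetero atoms, one six-membered aromatic ring with 1 hetero atom), on a carbonyl carbon. Going by the values given here, no measured pair shows this exact exchange, so only the structural change itself can guide the expectation. A modest rise in the number in this assay, or none beyond the scatter, is expected for the step of a 3.3-fold higher number from compound 1 to compound 4 (0.52 log units; beyond the scatter). Compound 4 is therefore estimated at 60 nM in this assay, with a range from 15 nM to 300 nM.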

Compound 4, half-maximal inhibitory concentration: 2 nM
Estimate against measurement, compound 4: 30-fold (1.48 log units) above, and the stated range ends above it.
By their numbers in this assay, from the lowest: compound 4; then compounds 1 and 2 (each within the scatter of the next). At a limit, above all of these: compound 3.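

Going by these compounds alone, the step of a 9.0-fold lower number from compound 1 to compound 4 (0.95 log units; beyond the scatter) in this assay is the first measured exchange in one place, so the heteroaryl on the carbonyl carbon can now be read on its own. With the rest of the molecule unchanged, the group with a six-membered aromatic ring with 2 hetero atoms, in place of the one with a six-membered aromatic ring with 1 hetero atom, gives a lower number, so this place responds to a single added ring nitrogen. Nothing shown here accounts for the size of this step.

The compounds shown leave open whether the same exchange would give a similar step with the trifluoromethyl-substituted aryl sulfone of compound 2. They also leave open how an amine or a carboxylic acid on the heteroaryl would read in this assay.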